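A few compounds are considered here, and "the series" means these few. Any claim that something is new, unique, unknown or untested is made for them only; others in the source may bear on it.

Measured so far:
compound 1 `CCOC(=O)c1c(-c2ccc(Cl)c(Cl)c2)cc(-c2ccccc2)nc1N1CCCCC1` — 48.9%
compound 2 `CCOC(=O)c1c(-c2ccc(Cl)cc2)cc(-c2ccccc2)nc1Nc1ccccc1` — 46.5%

In a functional assay on the whole organism (strain Wister albino) for inhibition, with Rattus norvegicus as the target, read by paw edema, with stated times of 1 h and 24 h, at a dose of 50 mg/kg by the intraperitoneal route (on this read-out higher numbers stand for more inhibition at the one dose given (going by the name of the read-out) and lower numbers for less inhibition), compound 2 gives 46.5% and compound 1 gives 48.9%; the two numbers lie within the scatter of each other, so neither can be set apart from the other. For the measured compounds named here, no two measured compounds differ in one place, so no step is known. Compound 3 `CCOC(=O)c1c(-c2ccc(Cl)cc2)cc(-c2ccccc2)nc1Nc1ccc(OC)cc1` follows from compound 2 by methoxy in place of hydrogen on an aromatic carbon. Going by the values given here, with no measured step to lean on, the expected step is a number 1.5 percentage points lower from compound 2 to compound 3 (within the scatter), none beyond the scatter. Compound 3 is estimated at 45% in this assay, within 30% to 60%.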

Compound 3, a percentage reported as inhibition, in the whole organism at one dose (the size of the read-out at that dose, not a potency): 39.6%
Beside the measured number, compound 3's estimate is 5.4 percentage points above it; measured number inside the range.
By their numbers in this assay, from the lowest: compounds 3, 2 and 1 (each within the scatter of the next).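

In this assay, for the compounds shown here, the change from anilino to (4-methoxyphenyl)amino gives the first one-place step, a number 6.9 percentage points lower from compound 2 to compound 3 (within the scatter), so methoxy on this aromatic carbon, para to a large group, cannot be set apart from hydrogen. This single step gives no sign that the position needs the unsubstituted ring. No available evidence bears on this result.

From the compounds shown here alone, whether an amine, a carboxylic acid or a longer alkoxy chain at this place would give a step beyond the scatter remains open. One step alone sets no trend for this position.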